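A few compounds are considered here, and "the series" means these few. Any claim that something is new, unique, unknown or untested is made for them only; others in the source may bear on it.

In an ADME assay on cells (Hepatocyte, Mus musculus) for metabolic stability, read by LC-MS, with a stated time of 180 min, tested at 1 uM (a lower number here means slower removal, a higher number faster removal of the compound), compound 2 (`O=C(O)Cc1nn(Cc2cn3cc(OCC4CC4)c(Cl)cc3n2)c2ccccc2c1=O`) gives 30 mL/min/kg, the lower of the two actual numbers in the series. Compound 3 (`C[C@H](C(=O)O)n1nc(Cn2cc3cc(OCC4CC4)c(Cl)cc3n2)c2ccccc2c1=O`) gives 63.3 mL/min/kg, a higher number, and the gap between the two lies beyond the usual scatter. Compound 1 (`O=C(O)Cn1nc(Cc2nc3cc(Cl)c(OC(F)(F)F)cc3[nH]2)c2ccccc2c1=O`) gives < 38.4 mL/min/kg, which is a limit of the assay and not a number, so it cannot be ranked against the other two.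

The next compound to be read is compound 4 (`CCC(C(=O)O)c1nn(Cc2cn3cc(OCC4CC4)c(Cl)cc3n2)c2ccccc2c1=O`). Its difference from compound 2 is ethyl in place of hydrogen on a saturated chain carbon bound to an aromatic carbon and a carbonyl carbon, so that carboxymethyl becomes 1-carboxypropyl.

Within the data shown here, no measured pair isolates this change, so the expectation rests on thin ground. The nearest hint is indirect: differing from compound 2 in more than one place, and also lacking the plain carboxymethyl, compound 3 gives 63.3 mL/min/kg in this assay. A modest rise is therefore expected, possibly still within the scatter, and the estimated size is a 1.5-fold higher number from compound 2 to compound 4 (0.18 log units; within the scatter). For compound 4 the estimated clearance is 45 mL/min/kg, with an expected range of 22 mL/min/kg to 90 mL/min/kg.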

Compound 4, clearance: 155 mL/min/kg
Beside the measured number, compound 4's estimate is 3.4-fold (0.54 log units) below it, outside the stated range (above it).
By their numbers in this assay, from the lowest: compound 2; then compound 3; then compound 4.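

The saturated chain carbon bound to an aromatic carbon and a carbonyl carbon is not a silent position in this assay: ethyl in place of hydrogen there, turning carboxymethyl into 1-carboxypropyl, gives a 5.2-fold higher number from compound 2 to compound 4 (0.71 log units; beyond the scatter). Among these compounds, the earlier compounds all differ from one another in more than one place, so this is the only step that reads this position on its own, and it shows that adding 2 carbon atoms, with no ring, no hydrogen-bond donors or acceptors and no net charge, is enough to move the number beyond the scatter. Nothing measured here bears on why the number rises, so the step stands as an observation only.

Compound 1 gives < 38.4 mL/min/kg, which is a limit of the assay and not a number, and it adds nothing to this reading. Going by these compounds, with a single substituent read at this carbon, it remains open whether the rise depends on the size of the group, or how a hydroxyl, a fluorine or a longer chain such as butyl would behave in the same place.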